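The source may hold more compounds than are shown below. What is called first, only, known or untested is meant among the compounds shown, and "the series" means these compounds.

Compound 3 `N=C(NCCCc1c[nH]cn1)NC(=O)CC(c1ccccc1)c1ccccc1` is tested in a functional assay on cardiac atrium for agonist activity at histamine H2 receptor (Cavia porcellus) (on this read-out lower numbers stand for an effect already at smaller amounts and higher numbers for an effect only at larger amounts of compound), where it gives 28.2 nM. Compound 2 `Cc1[nH]cnc1CSCC(=O)NC(=N)NCCCc1c[nH]cn1` gives 30.9 nM in this assay, a number within the scatter of that of compound 3. Compound 1 `N=C(NCCCc1c[nH]cn1)NCCC(c1ccc(F)cc1)c1ccccn1` gives 9.77 nM, and its separation from compound 3 lies beyond the scatter. So compound 3 stands with the second highest number of the three, close to compound 2 and further from compound 1.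

Compound 4 `N=C(NCCCc1c[nH]cn1)NC(=O)CC(c1ccccc1)c1ccc(F)cc1` differs from compound 3 by fluoro in place of hydrogen on an aromatic carbon. For the measured compounds named here, no measured pair shows this change directly. A step of small size, inside the scatter, is expected in either direction, as a 1.1-fold lower number from compound 3 to compound 4 (0.05 log units; within the scatter). For compound 4, this assay is estimated to give 25 nM, with a range from 10 nM to 60 nM.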

Compound 4, half-maximal effective concentration: 55 nM
Beside the measured number, compound 4's estimate is 2.2-fold (0.34 log units) below it; low and high end bracket the measured number.
By their numbers in this assay, from the lowest: compound 1; then compounds 3, 2 and 4 (each within the scatter of the next).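

Fluoro in place of hydrogen on an aromatic carbon, para to a large group, gives a 2.0-fold higher number from compound 3 to compound 4 (0.29 log units; within the scatter) in this assay. This is the first direct reading of this change among the compounds shown, and the two numbers cannot be told apart from repeat-measurement noise, so this position accepts fluoro without a clear shift. Nothing available explains this result. Still open, going by these compounds, is whether a larger group at the same place, such as chloro, methoxy or an amine, would stay within the scatter of compound 3.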